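Swapping Chloro for Nitro at the Assay Ceiling

This account rests on a few compounds, and the source may have more. Where it says the series, first, only, none or still open, it means among the compounds named here.

Three measured compounds share one core. Compound 1 `Cc1cccc(-n2nncc2CN2C(=O)C3(C(C#N)=C(N)Oc4c3c3nc5ccccc5nc3c3ccccc43)c3ccccc32)c1` gives 39600 nM in a functional assay on A549 cells (Homo sapiens) for antiproliferative activity, read by MTT assay, with a stated time of 48 h; on this read-out higher numbers stand for weaker inhibition and lower numbers for stronger inhibition. Compound 2 `N#CC1=C(N)Oc2c(c3nc4ccccc4nc3c3ccccc23)C12C(=O)N(Cc1cnnn1-c1ccc(Cl)cc1)c1ccccc12` gives in this assay only a limit, > 50000 nM. Compound 2 thus sits at the limit of > 50000 nM in this assay, at which 2 of the 3 values shown sit. Compound 3 `COc1ccccc1-n1nncc1CN1C(=O)C2(C(C#N)=C(N)Oc3c2c2nc4ccccc4nc2c2ccccc32)c2ccccc21` likewise gives only a limit, > 50000 nM. The steps of an at least 1.2-fold higher number from compound 1 to compound 2 (0.10 log units; that floor lies within the scatter) and an at least 1.2-fold higher number from compound 1 to compound 3 (0.10 log units; that floor lies within the scatter) are floors only, and a step that the two limits leave unreadable from compound 2 to compound 3 cannot be read. Compound 4 `N#CC1=C(N)Oc2c(c3nc4ccccc4nc3c3ccccc23)C12C(=O)N(Cc1cnnn1-c1ccc([N+](=O)[O-])cc1)c1ccccc12` differs from compound 2 by nitro in place of chloro on an aromatic carbon. Going by the values given here, no measured step alters this group, so none bears on it directly; all measured compounds sit at or close to the limit, and compound 4 is expected to do the same, with a number no higher from compound 2 to compound 4 (the limit leaves the size open) as the expected step. Compound 4 is therefore estimated at 50000 nM, between 20000 nM and 150000 nM.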

Compound 4, half-maximal inhibitory concentration: > 50000 nM
Compound 4: a limit, no number (the forecaster's own chance of this, stated with the estimate: 70%); the middle value sits exactly at the limit.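

Compound 4 adds a third aryl group on this aromatic nitrogen that gives only a limit in this assay, so nitro, like chloro, yields no readable number here. Against compound 1, the only compound with a number, the change gives a floor only: an at least 1.2-fold higher number from compound 1 to compound 4 (0.10 log units; that floor lies within the scatter). The steps linking compound 4 to compound 2 and compound 3 cannot be read, and the limit now holds most of the set: the limit of > 50000 nM in this assay, at which 3 of the 4 values shown sit.

From the compounds shown here alone, what an amine or a carboxylic acid in place of nitro would give stays open. Also open, going by these compounds, is whether compound 1 truly differs from the other three beyond the usual scatter.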